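From Butoxy to Isobutoxy on a Shared Core

A few compounds are considered here, and "the series" means these few. Any claim that something is new, unique, unknown or untested is made for them only; others in the source may bear on it.

Measured in a functional assay on the whole organism with Rattus norvegicus as the target; a lower number here means that less compound is needed, a higher number that more compound is needed for the effect:
Compound 1 `COc1ccccc1-c1ncc(-c2nn[nH]n2)c(O)n1`: 0.1 mg/kg
Compound 2 `CCCCOc1ccccc1-c1ncc(-c2nn[nH]n2)c(O)n1`: 0.07 mg/kg

Among the measured compounds shown here, compound 2 stands within the scatter of compound 1, the only other compound measured. Compound 3 `CC(C)COc1ccccc1-c1ncc(-c2nn[nH]n2)c(O)n1` turns the butoxy of compound 2 into isobutoxy: isopropyl in place of propyl on a saturated chain carbon bound to an oxygen on an aromatic ring. For the measured compounds named here, the one measured step bearing on this, a 1.4-fold lower number from compound 1 to compound 2 (0.15 log units; within the scatter), put propyl in place of hydrogen on a saturated chain carbon bound to an oxygen on an aromatic ring, so no step beyond the scatter is expected in this assay for compound 3. The expected step is a 1.1-fold higher number from compound 2 to compound 3 (0.06 log units; within the scatter). Compound 3 is estimated at 0.08 mg/kg, with an expected range from 0.03 mg/kg to 0.2 mg/kg.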

Compound 3, dose for 50% inhibition: 0.1 mg/kg
The estimate for compound 3 lay 1.3-fold (0.10 log units) below the measured number; low and high end bracket the measured number.
By their numbers in this assay, from the lowest: compounds 2, 1 and 3 (each within the scatter of the next).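

In this assay, the position on a saturated chain carbon bound to an oxygen on an aromatic ring now carries a branched chain as well as a straight one: the data show a 1.4-fold higher number from compound 2 to compound 3 (0.15 log units; within the scatter), and no change at the digits printed from compound 1 to compound 3 (within the scatter). Both steps lie within the scatter, so isobutoxy, butoxy and the methoxy of compound 1 cannot be separated here. Nothing available explains this flat result. As far as these compounds go, whether a longer chain such as hexyl, or a chain carrying an amine, would move the number beyond the scatter stays open.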